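Trading bromo for chloro on one aromatic carbon

The source may report more compounds than this note shows. Statements on the series, on what has been measured and on what is new or still open speak of the compounds shown alone.

Compound 1 `COc1ccc(C(=O)Nc2nnc(/C=C/c3cc(OC)c(OC)c(OC)c3Br)s2)cc1` gives 150 nM
Compound 2 `COc1cc(/C=C/c2nnc(NC(=O)c3ccccc3Br)s2)c(Br)c(OC)c1OC` gives 210 nM
Compound 3 `COc1cc(/C=C/c2nnc(NC(=O)c3ccc(Br)cc3)s2)c(Br)c(OC)c1OC` gives 160 nM

In a functional assay on A549 cells (Homo sapiens) for antiproliferative activity, read by MTT assay, with a stated time of 48 h (on this read-out lower numbers stand for stronger inhibition and higher numbers for weaker inhibition), compound 3 gives 160 nM and sits within the scatter of both other compounds, so the three values cannot be ranked. Compound 4 `COc1cc(/C=C/c2nnc(NC(=O)c3ccc(Cl)cc3)s2)c(Br)c(OC)c1OC` differs from compound 3 at one spot, counted as chloro in place of bromo on an aromatic carbon and amounting to chloro in place of bromo on an aromatic carbon, para to a large group. Among the compounds with values here, no measured step makes this exact swap. The closest evidence comes from changes at the same phenyl group: a 1.1-fold higher number from compound 1 to compound 3 (0.03 log units; within the scatter) for bromo in place of methoxy, a 1.3-fold lower number from compound 2 to compound 3 (0.12 log units; within the scatter) for 4-bromophenyl in place of 2-bromophenyl, and a 1.4-fold higher number from compound 1 to compound 2 (0.15 log units; within the scatter) for 2-bromophenyl in place of 4-methoxyphenyl. All three stay within the scatter. The new swap exchanges only one atom for one atom, so no step beyond the scatter is expected in this assay and no direction can be called. The expected step is no change at the digits printed from compound 3 to compound 4 (within the scatter) and nothing larger. The estimated value for compound 4 is 160 nM with 85 nM to 300 nM as its likely range.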

Compound 4, half-maximal inhibitory concentration: 140 nM
Beside the measured number, compound 4's estimate is 1.1-fold (0.06 log units) above it; the range from low to high includes it.
By their numbers in this assay, from the lowest: compounds 4, 1, 3 and 2 (each within the scatter of the next).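

In this assay the change from 4-bromophenyl to 4-chlorophenyl gives a 1.1-fold lower number from compound 3 to compound 4 (0.06 log units; within the scatter), so chloro and bromo cannot be told apart at this place, para to a large group. The comparisons with the other two compounds read the same way: chloro in place of methoxy gives a 1.1-fold lower number from compound 1 to compound 4 (0.03 log units; within the scatter), and 4-chlorophenyl in place of 2-bromophenyl gives a 1.5-fold lower number from compound 2 to compound 4 (0.18 log units; within the scatter), so the new compound adds a fourth group on this phenyl ring without any step beyond the scatter. No measurement shown here offers an explanation for this flat result.

The compounds shown cover only bromo, chloro and methoxy at this place, plus bromo in a different position on the ring. As far as these compounds go, whether an amine, a carboxylic acid or a longer chain such as butoxy at this place would step beyond the scatter remains open.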